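The compounds below may be only part of what the source reports. "The series", "measured", "known", "first", "only" and "open" are said of these compounds alone.

Working notes on the series in a functional assay on NCI-H460 cells (Homo sapiens) for inhibition, with a stated time of 72 h; a lower number here means a stronger inhibitor, a higher number a weaker inhibitor. Compound 1 (`COc1ccc(S(=O)(=O)N2CCc3cccc(-c4ccc(N)cc4)c32)cc1`) gives 288 nM, compound 2 (`COc1ccc(S(=O)(=O)N2CCc3cccc(-c4ccco4)c32)cc1`) gives 94.5 nM, and compound 3 (`COc1ccc(S(=O)(=O)N2CCc3cccc(-c4ccc(N(C)C)cc4)c32)cc1`) gives 556 nM. This last number is the highest of the three, although a 1.9-fold higher number from compound 1 to compound 3 (0.29 log units; within the scatter) stays within the scatter, while a 5.9-fold higher number from compound 2 to compound 3 (0.77 log units; beyond the scatter) goes beyond it.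

The next compound is compound 4 (`COc1ccc(-c2cccc3c2N(S(=O)(=O)c2ccc(OC)cc2)CC3)cc1`), and the change is methoxy in place of dimethylamino on an aromatic carbon, para to a large group. The measured step that touches the same group is a 1.9-fold higher number from compound 1 to compound 3 (0.29 log units; within the scatter). The steps of a 3.0-fold lower number from compound 1 to compound 2 (0.48 log units; beyond the scatter) and a 5.9-fold higher number from compound 2 to compound 3 (0.77 log units; beyond the scatter) exchange the whole substituted phenyl for furan-2-yl, so they bear on this change less directly. With only a small step on record for a swap at this group, no step beyond the scatter is expected in this assay, with a slight lean towards a lower number. The estimated step is a 1.6-fold lower number from compound 3 to compound 4 (0.20 log units; within the scatter). For compound 4 the expected value is 350 nM, with an estimated range of 130 nM to 800 nM.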

Compound 4, half-maximal inhibitory concentration: 302 nM
Beside the measured number, compound 4's estimate is 1.2-fold (0.06 log units) above it, within the range that was stated.
By their numbers in this assay, from the lowest: compound 2; then compounds 1, 4 and 3 (each within the scatter of the next).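

In this assay, methoxy in place of dimethylamino, on an aromatic carbon para to a large group, gives a 1.8-fold lower number from compound 3 to compound 4 (0.27 log units; within the scatter), and methoxy in place of amino at the same place gives a 1.0-fold higher number from compound 1 to compound 4 (0.02 log units; within the scatter). Amino, dimethylamino and methoxy at this place therefore cannot be told apart in this assay, and the swap of one for another has yet to produce a step beyond the scatter. Furan-2-yl remains apart from this set, now also with a 3.2-fold higher number from compound 2 to compound 4 (0.50 log units; beyond the scatter) for the change to 4-methoxyphenyl, and no measurement on hand accounts for either the flat reading or that gap.

As far as these compounds go, it remains open whether a carboxylic acid, a fluorine or a longer alkoxy chain at this place would leave the set unchanged. From the compounds shown here alone, it is also open whether the furan-2-yl result carries over to thiophen-2-yl or pyridin-3-yl.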